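The source may report more compounds than this note shows. Statements on the series, on what has been measured and on what is new or still open speak of the compounds shown alone.

Compound 2 `N#Cc1ccccc1CN1C(=O)N(Cc2ccccc2)S(=O)(=O)n2cccc21` stands at a limit in an ADME assay on MT4 cells (Homo sapiens) for cytotoxicity, read by MTT assay, with a stated time of 5 days; on this read-out higher numbers stand for lower toxicity in this test and lower numbers for higher toxicity in this test: its value of > 318000 nM is a limit of the test, not a number. Compound 1 `C=CCN1C(=O)N(Cc2ccccc2)S(=O)(=O)n2cccc21` likewise gives only a limit in this assay, > 802000 nM. Going by the values given here, compound 3 `O=C1N(Cc2ccccc2Cl)c2cccn2S(=O)(=O)N1Cc1cccc(F)c1` is the one compound with a measured number in this assay, 231000 nM. The change from compound 1 to compound 2 reads a step that the two limits leave unreadable from compound 1 to compound 2; its size stays hidden because both values are limits the limit of > 318000 nM in this assay, at which 1 of the 3 values shown sits (the limit of > 802000 nM in this assay, at which 1 of the 3 values shown sits).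

Compound 4 `CC(C)=CCN1C(=O)N(Cc2ccccc2)S(=O)(=O)n2cccc21` differs from compound 2 by 2-methylprop-1-en-1-yl in place of 2-cyanophenyl on a saturated chain carbon bound to an amide-type nitrogen in a ring. Among the compounds with values here, the only step touching this position is unreadable, so no shift beyond the scatter is expected, and a limit again seems likely. Compound 4 is expected to give 600000 nM, between 200000 nM and 1500000 nM, an expected step that the limit leaves unreadable from compound 2 to compound 4.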

Compound 4, half-maximal cytotoxic concentration: 226000 nM
For compound 4 the middle estimate is 2.7-fold (0.42 log units) above the measured one; measured number inside the range.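

In this assay, this position now gives its first readable step: 3-methylbut-2-en-1-yl in place of the shorter chain gives an at least 3.5-fold lower number from compound 1 to compound 4 (0.55 log units; beyond the scatter), while in place of 2-cyanobenzyl it gives an at least 1.4-fold lower number from compound 2 to compound 4 (0.14 log units; that floor lies within the scatter). Compound 1 gives only a limit, so the first step is a minimum size: the limit of > 802000 nM in this assay, at which 1 of the 4 values shown sits. Compound 2 also gives only a limit, so the second step is a minimum size too: the limit of > 318000 nM in this assay, at which 1 of the 4 values shown sits.

Going by these compounds, the full size of both steps stays open. So does how the number would move with an amine or a carboxylic acid at this position.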